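Swapping a Bromine for Trifluoromethyl on the Benzyl Ring

The source may report more compounds than this note shows. Statements on the series, on what has been measured and on what is new or still open speak of the compounds shown alone.

Measured so far:
compound 1, `O=C(O)CCc1ccc(OCc2ccccc2)c(I)c1`, 12600 nM
compound 2, `O=C(O)CCc1ccc(OCc2ccc(Br)cc2)cc1`, 550 nM
compound 3, `O=C(O)CCc1ccc(OCc2cccc(Br)c2)cc1`, 89.1 nM

All three compounds were tested in a functional assay on 1321-N1 cells for agonist activity at Free fatty acid receptor 1 (Homo sapiens), read by calcium flux; a lower number here means that less compound is needed, a higher number that more compound is needed for the effect. Compound 3 gives the lowest number of the three, and both of its neighbours lie well apart from it: compound 2 sits at 550 nM, and compound 1 at 12600 nM, each a gap beyond the usual scatter. Compound 3 is therefore the most potent compound among those measured.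

The next compound, compound 4, `O=C(O)CCc1ccc(OCc2cccc(C(F)(F)F)c2)cc1`, has not yet been measured in this assay. It differs from compound 3 in a single place: trifluoromethyl in place of bromo on an aromatic carbon. The shared core, the linking chain and the acid are unchanged.

Among the compounds with values here, no measured pair in this set shows a step of exactly this kind, so any expectation rests on the general picture that a single substituent on the benzyl ring at this position already gives a low number in compound 3. The step from compound 3 to compound 4 is expected to be small, at most a modest rise, and likely within the scatter: a 1.7-fold higher number from compound 3 to compound 4 (0.23 log units; within the scatter). Compound 4 is expected to give about 150 nM in this assay, with a plausible range from 50 nM to 500 nM.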

Compound 4, half-maximal effective concentration: 83.2 nM
For compound 4 the middle estimate is 1.8-fold (0.26 log units) above the measured one; low and high end bracket the measured number.
By their numbers in this assay, from the lowest: compounds 4 and 3 (each within the scatter of the next); then compound 2; then compound 1.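

In this assay, trifluoromethyl in place of bromo on an aromatic carbon, meta to a large group, gives a 1.1-fold lower number from compound 3 to compound 4 (0.03 log units; within the scatter), so the two compounds cannot be told apart. Within the data shown here, this is the first step in the set between compounds that differ in one place, and it shows that, at this position, a group of four heavy atoms and a single bromine atom give matching numbers. Nothing measured here speaks to what lies behind this match.

The compounds shown leave open whether this match extends beyond these two groups, for example to a methoxy group, a nitrile, an amine or a longer chain at the same place, or whether it is limited to bromo and trifluoromethyl. They also leave open whether trifluoromethyl would match bromo at the place that carries the bromine in compound 2, which gives a higher number of 550 nM, so the finding cannot yet be carried over to other places on the benzyl ring.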